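The source may report more compounds than this note shows. Statements on the series, on what has been measured and on what is new or still open speak of the compounds shown alone.

Measured compounds:
- compound 1 `COc1cc(OC)cc(/C(=C\c2cn(C(C)=O)c3ccc(OCc4ccccc4)cc23)C(=O)O)c1`: 30400 nM
- compound 2 `CC(=O)n1cc(/C=C(/C(=O)O)c2ccc(Cl)cc2)c2cc(OCc3ccccc3)ccc21`: > 100000 nM

In a functional assay on KB cells (Homo sapiens) for cytotoxicity, read by MTT assay, with a stated time of 72 h (on this read-out lower numbers stand for stronger inhibition and higher numbers for weaker inhibition), compound 1 gives 30400 nM. In this assay compound 2 reaches only a limit, > 100000 nM, and so stands at the limit of > 100000 nM in this assay, at which 1 of the 2 values shown sits; it is therefore the less active of the two shown, but by an amount that cannot be fixed beyond that limit. Among the measured compounds shown here, the one measured step, an at least 3.2-fold higher number from compound 1 to compound 2 (0.51 log units; beyond the scatter), concerns an exchange of the aryl group on the chain carbon, not a substituent change on that aryl group.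

Compound 3 `CC(=O)n1cc(/C=C(/C(=O)O)c2ccc(OCc3ccccc3)cc2)c2cc(OCc3ccccc3)ccc21` is not yet measured. It differs from compound 2 by benzyloxy in place of chloro on an aromatic carbon. For the measured compounds named here, no measured step addresses a substituent change of this kind on the aryl group, so there is no direct guide; the only measured step shows that the identity of the aryl group on the chain carbon moves this assay by at least a modest amount. Compound 3 is expected to land somewhere between the two measured compounds, as a step of an at least 1.6-fold lower number from compound 2 to compound 3 (0.22 log units; that floor lies within the scatter), with a real chance that this assay again returns only a limit. The estimate for compound 3 is 60000 nM, within 15000 nM to 300000 nM.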

Compound 3, half-maximal inhibitory concentration: 43000 nM
The estimate for compound 3 lay 1.4-fold (0.14 log units) above the measured number; the range from low to high includes it.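

In this assay, benzyloxy in place of chloro on the aromatic carbon para to a large group gives an at least 2.3-fold lower number from compound 2 to compound 3 (0.36 log units; beyond the scatter), so a substituent exchange on this aryl group moves the read-out, and not only an exchange of the whole aryl group. The size of this step has a floor but no upper bound, as compound 2 holds a limit and not a number: the limit of > 100000 nM in this assay, at which 1 of the 3 values shown sits.

Compound 1 gives 30400 nM and compound 3 gives 43000 nM, two values within the usual scatter of each other, so the 3,5-dimethoxyphenyl group and the aryl group carrying benzyloxy cannot be ranked in this read-out.

Still open, as far as these compounds go, is whether the change in compound 3 follows from the ether oxygen or from the added aromatic ring, a question that a hydroxyl, an ethoxy or an amine at the same carbon would bear on. Also open, from the compounds shown here alone, is how far the carboxylic acid on the chain matters, since all three compounds carry it and an ester or a primary amide there would test its part in the values seen.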